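A few compounds are considered here, and "the series" means these few. Any claim that something is new, unique, unknown or untested is made for them only; others in the source may bear on it.

Working notes on the series. In a functional assay on cells (Homo sapiens) for cytotoxicity, read by MTT assay, with a stated time of 24 h (on this read-out higher numbers stand for weaker inhibition and lower numbers for stronger inhibition), compound 1 `CCCCCCCCCCCCCCNC(=O)[C@H](CO)/N=C/c1cccc(C)c1` gives 82900 nM, compound 2 `CCCCCCCCCCCCCCNC(=O)[C@H](CO)/N=C/c1ccc(OC)cc1` gives 28100 nM and compound 3 `CCCCCCCCCCCCCCNC(=O)[C@H](CO)/N=C/c1ccccc1[N+](=O)[O-]` gives 21700 nM. Compound 2 and compound 3 form the lower pair of these three numbers, with a 1.3-fold lower number from compound 2 to compound 3 (0.11 log units; within the scatter) separating them, while compound 1 stands apart at a 3.0-fold lower number from compound 1 to compound 2 (0.47 log units; beyond the scatter).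

The next structure is compound 4 `CCCCCCCCCCCCCCNC(=O)[C@H](CO)NCc1ccccc1OC`. The change is a group of 10 heavy atoms (8 carbon, 1 nitrogen, 1 oxygen; one six-membered aromatic ring of carbon only) in place of a group of 10 heavy atoms (8 carbon, 1 nitrogen, 1 oxygen; one six-membered aromatic ring of carbon only), on a saturated chain carbon bound to a carbonyl carbon and a saturated chain carbon. The group that enters is (2-methoxybenzyl)amino.

Among the compounds with values here, the measured steps only exchange one substituted phenyl group for another on the carbon with a double bond to nitrogen, and no measured step covers the loss of that double bond. They therefore bear on the change only in part. The largest of them, a 3.8-fold lower number from compound 1 to compound 3 (0.58 log units; beyond the scatter), sets the size of step expected in this assay, and the direction is uncertain, with a slight lean towards a lower number. The expected change is a 1.5-fold lower number from compound 2 to compound 4 (0.17 log units; within the scatter). For compound 4 the estimate is 19000 nM, with an expected range from 7000 nM to 50000 nM.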

Compound 4, half-maximal inhibitory concentration: 100000 nM
For compound 4 the middle estimate is 5.3-fold (0.72 log units) below the measured one, outside the stated range (above it).
By their numbers in this assay, from the lowest: compounds 3 and 2 (each within the scatter of the next); then compounds 1 and 4 (each within the scatter of the next).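

In this assay, within the data shown here, the (2-methoxybenzyl)amino group on the saturated chain carbon bound to a carbonyl carbon and a saturated chain carbon gives a 3.6-fold higher number from compound 2 to compound 4 (0.55 log units; beyond the scatter), so this position tolerates a change that goes with weaker inhibition, whereas the earlier steps only exchanged one substituted phenyl group for another. Set against the imine-bearing compound 1, the same position gives a 1.2-fold higher number from compound 1 to compound 4 (0.08 log units; within the scatter), which places compound 4 level with compound 1 rather than with the lower pair. No measured evidence on the series bears on the reason for this shift.

On these data alone, the step from compound 2 also combines the loss of the double bond with a different methoxy placement, so the share of each remains open. A (4-methoxybenzyl)amino group or a free amine at this position would help separate the two.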